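The source may hold more compounds than are shown below. What is called first, only, known or untested is meant among the compounds shown, and "the series" means these compounds.

For the measured compounds named here, in a physicochemical assay for solubility, in phosphate buffer, at pH 7.4 (on this read-out lower numbers stand for lower solubility and higher numbers for higher solubility), two compounds with a shared core have numbers so far. Compound 1 (`OC1CCN(c2nccnc2OC2CN(c3ccc4ccccc4n3)C2)CC1`) gives 99000 nM, and compound 2 (`OC1CN(c2nccnc2OC2CN(c3ccc4ccccc4n3)C2)C1`) gives 41000 nM, the lower of the two. Compound 3 (`COCC1CCN(c2nccnc2OC2CN(c3ccc4ccccc4n3)C2)CC1`) has not yet been measured. It differs from compound 2 by 4-(methoxymethyl)piperidin-1-yl in place of 3-hydroxyazetidin-1-yl on an aromatic carbon, with 4-(methoxymethyl)piperidin-1-yl in place of 3-hydroxyazetidin-1-yl on an aromatic carbon.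

Going by the values given here, only one measured step bears on this change: a 2.4-fold lower number from compound 1 to compound 2 (0.38 log units; beyond the scatter), a modest step beyond the scatter. Read backwards, that step would point to a higher number for compound 3, which regains a six-membered non-aromatic ring. Among the compounds with values here, that reading is weak, however, since the hydroxy group is also lost, and no measured step shows what replacing it with methoxymethyl does. The two considerations leave a small step with a slight lean downward, and none clearly beyond the scatter is expected. The estimated change is a 1.4-fold lower number from compound 2 to compound 3 (0.14 log units; within the scatter). For compound 3 the expected value is 30000 nM, with an estimated range of 8000 nM to 90000 nM.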

Compound 3, solubility: 53000 nM
Compound 3: the middle estimate sits 1.8-fold (0.25 log units) below what was measured; low and high end bracket the measured number.
By their numbers in this assay, from the lowest: compounds 2, 3 and 1 (each within the scatter of the next, the first and the last beyond it).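

In this assay, placing 4-(methoxymethyl)piperidin-1-yl instead of 3-hydroxyazetidin-1-yl on this aromatic carbon gives a 1.3-fold higher number from compound 2 to compound 3 (0.11 log units; within the scatter), so the read-out does not separate these two groups, although one carries a hydrogen-bond donor and the other carries none. For the compounds shown here, with the six-membered non-aromatic ring kept, methoxymethyl in place of hydroxy on a saturated ring carbon gives a 1.9-fold lower number from compound 1 to compound 3 (0.27 log units; within the scatter), which offers the first direct look at that exchange and likewise stays inside the scatter; compound 3 therefore lies within the scatter of both compound 1 and compound 2, even though those two lie beyond it from each other. Nothing available explains these numbers.

The compounds shown leave open what an amine or a carboxylic acid in place of methoxymethyl on that saturated ring carbon would do to the number. They also leave open whether a longer ether chain there would give a step beyond the scatter, and how methoxymethyl would read on the four-membered ring of compound 2.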